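Benzyl arm substituent swap: methyl to methoxy

A few compounds are considered here, and "the series" means these few. Any claim that something is new, unique, unknown or untested is made for them only; others in the source may bear on it.

In an assay on isolated protein for inhibition of protein deacetylase HDAC6 (Homo sapiens), read by fluorescence, with stated times of 10 min and 2 h (a higher number here means a weaker inhibitor, a lower number a stronger inhibitor), compound 1 `CCCC1(c2ccccc2)NC(=O)N(Cc2ccc(C(=O)NO)cc2)C1=O` gives 50.9 nM and compound 2 `O=C(NO)c1ccc(CN2C(=O)NC(Cc3ccc(Cl)cc3)(c3ccccc3)C2=O)cc1` gives 54 nM. Compound 3 `Cc1ccc(CC2(c3ccccc3)NC(=O)N(Cc3ccc(C(=O)NO)cc3)C2=O)cc1` gives 82.4 nM in this assay; of the three numbers this is the highest, yet a 1.6-fold higher number from compound 1 to compound 3 (0.21 log units; within the scatter) and a 1.5-fold higher number from compound 2 to compound 3 (0.18 log units; within the scatter) both lie within the scatter, so no ranking follows. Compound 4 `COc1ccc(CC2(c3ccccc3)NC(=O)N(Cc3ccc(C(=O)NO)cc3)C2=O)cc1` differs from compound 3 by methoxy in place of methyl on an aromatic carbon, on an aromatic carbon of a six-membered aromatic ring of carbon only, para to a large group. The step that bears most directly, a 1.5-fold higher number from compound 2 to compound 3 (0.18 log units; within the scatter), exchanged groups at this same aromatic carbon without leaving the scatter, and a 1.6-fold higher number from compound 1 to compound 3 (0.21 log units; within the scatter) was likewise within it. No step beyond the scatter is therefore expected for a 1.0-fold higher number from compound 3 to compound 4 (0.01 log units; within the scatter). Compound 4 is estimated at 85 nM, within a range of 40 nM to 180 nM.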

Compound 4, half-maximal inhibitory concentration: 72.4 nM
Compound 4: the middle estimate sits 1.2-fold (0.07 log units) above what was measured, and the stated range covers the measured number.
By their numbers in this assay, from the lowest: compounds 1, 2, 4 and 3 (each within the scatter of the next).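

At this aromatic carbon methoxy brings a hydrogen-bond acceptor where methyl has none, and a 1.1-fold lower number from compound 3 to compound 4 (0.06 log units; within the scatter) follows, with a 1.3-fold higher number from compound 2 to compound 4 (0.13 log units; within the scatter) against chloro. Measured against ethyl on the saturated chain carbon, 4-methoxyphenyl gives a 1.4-fold higher number from compound 1 to compound 4 (0.15 log units; within the scatter) and so all four compounds lie within the scatter of one another. Nothing available explains these numbers.

On these data alone, whether an amine or a carboxylic acid on this aromatic carbon would step beyond the scatter stays open. So does the effect of a longer chain in place of the ethyl.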